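The source may report more compounds than this note shows. Statements on the series, on what has been measured and on what is new or still open speak of the compounds shown alone.

The study opens with compound 1 `O=C1CS/C(=N\c2csc(-c3ccccc3)c2)N1`, whose result in a functional assay on HT-29 cells (Homo sapiens) for cytotoxicity, read by MTT assay, with a stated time of 72 h (on this read-out lower numbers stand for stronger inhibition and higher numbers for weaker inhibition), is only a limit, > 50000 nM (the limit of > 50000 nM in this assay, at which 1 of the 3 values shown sits). Among the compounds with values here, compound 2 `O=C1CS/C(=N\c2csc(-c3ccc(Cl)cc3)c2)N1` gives a number in this assay, 17100 nM, and the change of an at least 2.9-fold lower number from compound 1 to compound 2 (0.46 log units; beyond the scatter) is the one measured step in the set. Compound 3 `O=C1N/C(=N/c2csc(-c3ccc(Cl)cc3)c2)S/C1=C\c1ccccc1` gives 10500 nM in this assay; its number sits alongside that of compound 2, the two lying within the usual scatter of each other. Compound 1, by contrast, contributes only a limit.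

Compound 4 `O=C1N/C(=N/c2csc(-c3ccc(Cl)cc3)c2)S/C1=C\c1ccc(Br)cc1` differs from compound 3 by bromo in place of hydrogen on an aromatic carbon. Within the data shown here, no measured pair repeats this change on this ring; the only step that resembles it is a halogen entering a phenyl ring, and because an at least 2.9-fold lower number from compound 1 to compound 2 (0.46 log units; beyond the scatter) was at least modest, a similar or smaller lowering is expected here, possibly none beyond the scatter. Compound 4 is therefore expected to give about 7000 nM in this assay, between 2500 nM and 20000 nM. That estimate amounts to a 1.5-fold lower number from compound 3 to compound 4 (0.18 log units; within the scatter).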

Compound 4, half-maximal inhibitory concentration: 2000 nM
Compound 4: the middle estimate sits 3.5-fold (0.54 log units) above what was measured, outside the stated range (below it).
By their numbers in this assay, from the lowest: compound 4; then compounds 3 and 2 (each within the scatter of the next). At a limit, above all of these: compound 1.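

Within the data shown here, the step of a 5.3-fold lower number from compound 3 to compound 4 (0.72 log units; beyond the scatter) is the first sign in this assay that this phenyl group responds to substitution, with bromo on an aromatic carbon, para to a large group, moving the number beyond the scatter. Among these compounds, the only earlier step, an at least 2.9-fold lower number from compound 1 to compound 2 (0.46 log units; beyond the scatter), placed chloro on a different ring, so a halogen has now lowered the number at two separate places. Nothing measured here accounts for the size of this step.

The compounds shown leave open whether the lowering is specific to bromo or would also follow from chloro, a methoxy group, an amine or a carboxylic acid at the same place. They also leave open whether bromo on another carbon of this ring would give a similar step, and whether the step would persist without the chloro on the other ring.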